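Swapping Ethoxycarbonyl for Hydroxymethyl in a Cytotoxicity Test

A few compounds are considered here, and "the series" means these few. Any claim that something is new, unique, unknown or untested is made for them only; others in the source may bear on it.

Of the compounds shown here, two have been measured so far in a functional assay on HeLa cells (Homo sapiens) for cytotoxicity, read by MTT assay, with a stated time of 48 h; on this read-out lower numbers stand for stronger inhibition and higher numbers for weaker inhibition. Compound 1 (`COc1cc([C@@H]2C[C@]2(CO)C(=O)Nc2ccccc2Cl)cc(OC)c1OC`) gives 8100 nM, and compound 2 (`CCOC(=O)[C@@]1(C(=O)Nc2ccccc2Cl)C[C@H]1c1cc(OC)c(OC)c(OC)c1`) gives 14400 nM. These two numbers lie within the usual scatter of repeated measurements, so compound 2 stands level with compound 1 in this test.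

Compound 3 (`COc1cc([C@@H]2C[C@@]2(CO)C(=O)Nc2ccccc2Cl)cc(OC)c1OC`) is reached from compound 2 by a single exchange: hydroxymethyl in place of ethoxycarbonyl on a saturated ring carbon. Going by the values given here, no measured pair isolates this exchange, so its effect has to be judged indirectly. Compound 1 also carries a hydroxymethyl, and its 8100 nM gives the nearest guide. Compound 3 is a different compound, however, so that guide is only approximate. In this assay, no change beyond the scatter is expected, with at most a slight lean towards a lower number. The expected step is small: a 1.4-fold lower number from compound 2 to compound 3 (0.16 log units; within the scatter). For compound 3 the estimated value is 10000 nM, with an expected range from 3500 nM to 30000 nM.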

Compound 3, half-maximal inhibitory concentration: 13300 nM
Compound 3: the middle estimate sits 1.3-fold (0.12 log units) below what was measured, within the range that was stated.
By their numbers in this assay, from the lowest: compounds 1, 3 and 2 (each within the scatter of the next).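

In this assay, the exchange of ethoxycarbonyl for hydroxymethyl on this saturated ring carbon can now be read directly from a pair of compounds, and it gives a 1.1-fold lower number from compound 2 to compound 3 (0.03 log units; within the scatter). At this position, then, a hydroxymethyl with its hydrogen-bond donor and an ethoxycarbonyl without one give numbers that cannot be told apart in this test, so the exchange alone does not separate the two compounds. Going by these compounds alone, the drawn configuration at the same carbon can also be read for the first time, and it gives a 1.6-fold higher number from compound 1 to compound 3 (0.22 log units; within the scatter), a comparison that isolates this one feature: the fact that compounds 1 and 3 differ only in the configuration as drawn.

From the compounds shown here alone, it remains open whether a different group on this ring carbon, such as an amine, a carboxylic acid or a longer chain, would give a step beyond the scatter. Also open, going by these compounds, is what the other stereo element contributes, as it is drawn the same way in compound 1 and compound 3, and whether the same small steps would hold in a test other than this one.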